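Notes on a small series tested for inhibition of HepG2 cells

The compounds below may be only part of what the source reports. "The series", "measured", "known", "first", "only" and "open" are said of these compounds alone.

Measured compounds, with their values in a functional assay on HepG2 cells (Homo sapiens) for inhibition, read by MTT assay, with a stated time of 72 h; a lower number here means a stronger inhibitor, a higher number a weaker inhibitor:
compound 1, `CN(C(=O)NC(=O)c1ccccc1F)c1nc(C(F)(F)F)c(C(=O)N/N=C/c2cc(C(F)(F)F)cc(C(F)(F)F)c2)s1`, gives 4.47 ug/mL
compound 2, `CN(C(=O)NC(=O)c1cccc(C(F)(F)F)c1)c1nc(C(F)(F)F)c(C(=O)N/N=C/c2cc(C(F)(F)F)cc(C(F)(F)F)c2)s1`, gives 5.38 ug/mL
compound 3, `CN(C(=O)NC(=O)c1ccccc1F)c1nc(C(F)(F)F)c(C(=O)N/N=C/c2cccc(C(F)(F)F)c2)s1`, gives 20.3 ug/mL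

Compound 1 and compound 2 share the whole of their structure except one ring on the carbonyl carbon, the difference being (3-(trifluoromethyl)phenyl in place of 2-fluorophenyl on a carbonyl carbon). The step that goes with it, a 1.2-fold higher number from compound 1 to compound 2 (0.08 log units; within the scatter), lies within the scatter, so the two values are read as the same.

Compound 3 is built on the core of compound 1 with one group removed: hydrogen in place of trifluoromethyl on an aromatic carbon. Here the step is a 4.5-fold higher number from compound 1 to compound 3 (0.66 log units; beyond the scatter), beyond the scatter; compound 3 therefore stands with the highest number of the three, and its nearest neighbour by value is compound 2.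

Compound 4, `CN(C(=O)NC(=O)c1cccc(C(F)(F)F)c1)c1nc(C(F)(F)F)c(C(=O)N/N=C/c2cccc(C(F)(F)F)c2)s1`, is not yet measured. It carries the same change relative to compound 3 that compound 2 carries relative to compound 1: 3-(trifluoromethyl)phenyl in place of 2-fluorophenyl on a carbonyl carbon. The place is the same in both cases, a carbonyl carbon whose other neighbour is an amide-type nitrogen, so this change occurs twice in all among the four compounds.

Going by the values given here, for compound 4 in this assay the expected step from compound 3 is a 1.2-fold higher number from compound 3 to compound 4 (0.07 log units; within the scatter), a step expected to be small because the one measured instance of this change, a 1.2-fold higher number from compound 1 to compound 2 (0.08 log units; within the scatter), stayed within the scatter. Compound 4 is estimated at 24 ug/mL, with a likely range from 11 ug/mL to 52 ug/mL.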

Compound 4, half-maximal inhibitory concentration: 5.79 ug/mL
For compound 4 the middle estimate is 4.1-fold (0.62 log units) above the measured one, and the stated range ends above it.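

In this assay, 3-(trifluoromethyl)phenyl in place of 2-fluorophenyl on a carbonyl carbon gives a 3.5-fold lower number from compound 3 to compound 4 (0.54 log units; beyond the scatter), so this change did not carry over with the same size from one core to the other: the same change on two cores in this assay, a 1.2-fold higher number (0.08 log units; within the scatter) from compound 1 to compound 2 and a 3.5-fold lower number (0.54 log units; beyond the scatter) from compound 3 to compound 4, 4.2-fold (0.63 log units) apart, beyond the scatter of two such steps

Read along the other edge of the same four compounds, hydrogen in place of trifluoromethyl on an aromatic carbon gives a 1.1-fold higher number from compound 2 to compound 4 (0.03 log units; within the scatter), and this change does not carry over either: the same change on two cores in this assay, a 4.5-fold higher number (0.66 log units; beyond the scatter) from compound 1 to compound 3 and a 1.1-fold higher number (0.03 log units; within the scatter) from compound 2 to compound 4, 4.2-fold (0.63 log units) apart, beyond the scatter of two such steps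

The two gaps come from the same four values and count as one observation that, in this set, the size of each change depends on the group present at the other place; every step beyond the scatter has compound 3 at one end, so the data do not show whether this is a general feature of the series or rests largely on that one compound, and they give no reason for the gap.

Still open, as far as these compounds go, is whether the same dependence appears with other groups on that carbonyl carbon, such as an amine or a longer alkyl chain in place of the substituted phenyl. Also open, from the compounds shown here alone, is how a carboxylic acid in place of the trifluoromethyl on the aromatic carbon would behave on either core.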